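Two Small Changes on a Shared Core

The source may report more compounds than this note shows. Statements on the series, on what has been measured and on what is new or still open speak of the compounds shown alone.

Measured compounds:
compound 1, `N#C[C@@H]1CCCN1C(=O)[C@@H]1C[C@H](C(=O)N2CCCCC2)CN1`, 50%
compound 2, `CN(C)C(=O)[C@@H]1CN[C@H](C(=O)N2CCC[C@H]2C#N)C1`, 52%
compound 3, `C[C@@H]1N[C@H](C(=O)N2CCC[C@H]2C#N)C[C@@H]1C(=O)N1CCCCC1`, 81%

The three measured compounds were tested in an assay on the whole organism (plasma, strain Sprague-Dawley) for inhibition of Dipeptidyl peptidase 4 (Rattus norvegicus), with a stated time of 10 h, at a dose of 1 mg/kg by the oral route; on this read-out lower numbers stand for less inhibition and higher numbers for more inhibition at the one dose given (going by the name of the read-out). In this assay compound 1 gives 50%, compound 2 gives 52% and compound 3 gives 81%. The move from compound 1 to compound 2 is dimethylamino in place of piperidin-1-yl on a carbonyl carbon, and it gave a number 2 percentage points higher from compound 1 to compound 2 (within the scatter). The move from compound 1 to compound 3 is methyl in place of hydrogen on a saturated ring carbon, and it gave a number 31 percentage points higher from compound 1 to compound 3 (beyond the scatter). Compound 3 stands highest of the three, with both of its steps beyond the scatter.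

Compound 4, `C[C@@H]1N[C@H](C(=O)N2CCC[C@H]2C#N)C[C@@H]1C(=O)N(C)C`, has not yet been measured. It differs from compound 3 by dimethylamino in place of piperidin-1-yl on a carbonyl carbon. Among the measured compounds shown here, this is the same change as the one from compound 1 to compound 2, made on the same place, now on the methylated core of compound 3 rather than the core of compound 1.

Since that change gave a number 2 percentage points higher from compound 1 to compound 2 (within the scatter), compound 4 is expected to show a step of about no change at the digits printed from compound 3 to compound 4 (within the scatter). Compound 4 is therefore estimated at 81% in this assay, most likely between 64% and 92%.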

Compound 4, a percentage reported as inhibition, in the whole organism at one dose (the size of the read-out at that dose, not a potency): 84%
For compound 4 the middle estimate is 3 percentage points below the measured one; low and high end bracket the measured number.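

Replacing piperidin-1-yl with dimethylamino on the methylated core gave a number 3 percentage points higher from compound 3 to compound 4 (within the scatter), so in this assay this change on a carbonyl carbon read the same on both cores: the same change on two cores in this assay, a number 2 percentage points higher (within the scatter) from compound 1 to compound 2 and a number 3 percentage points higher (within the scatter) from compound 3 to compound 4, 1 percentage points apart, within the scatter of two such steps. Methyl in place of hydrogen on a saturated ring carbon gave a number 32 percentage points higher from compound 2 to compound 4 (beyond the scatter), and it also read the same with either group on the carbonyl carbon: the same change on two cores in this assay, a number 31 percentage points higher (beyond the scatter) from compound 1 to compound 3 and a number 32 percentage points higher (beyond the scatter) from compound 2 to compound 4, 1 percentage points apart, within the scatter of two such steps. Across these four compounds the two changes therefore appear to add up without affecting each other, but each comparison rests on a single pair of steps at one dose and one time, so this does not show that either change would carry to other cores or explain why the methyl step is large.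

The compounds shown leave open how morpholin-4-yl or diethylamino on the carbonyl carbon would behave on these two cores. They also leave open whether ethyl in place of methyl on the saturated ring carbon would give a step of similar size.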